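A Third Exchange on the Sulfur-Bound Chain Carbon

The compounds below may be only part of what the source reports. "The series", "measured", "known", "first", "only" and "open" are said of these compounds alone.

Three compounds built on one shared core have been examined in an assay on CHO cells for displacement of a labelled ligand from adenosine receptor A3 (Homo sapiens), read by scintillation counting, with a stated time of 120 min, tested at 1 uM; on this read-out lower numbers stand for less inhibition and higher numbers for more inhibition at the one concentration tested (going by the name of the read-out). Compound 1 `N#Cc1c(N)nc(SCc2cccc(C(N)=O)c2)c(C#N)c1-c1ccc(OCC2CC2)cc1` gives 1% in this assay. Compound 2 `N#Cc1c(N)nc(SCc2nnn[nH]2)c(C#N)c1-c1ccc(OCC2CC2)cc1`, which carries 1H-tetrazol-5-yl in place of 3-carbamoylphenyl on a saturated chain carbon bound to a sulfur, gives 1%, and the step of no change at the digits printed from compound 1 to compound 2 (within the scatter). Compound 3 `N#Cc1c(N)nc(SCn2cncn2)c(C#N)c1-c1ccc(OCC2CC2)cc1` gives 1% in this assay; the steps of no change at the digits printed from compound 1 to compound 3 (within the scatter) and no change at the digits printed from compound 2 to compound 3 (within the scatter) are likewise within the scatter. Compound 3 thus stands level with compounds 1 and 2, its nearest neighbour being compound 1 and its furthest compound 2, with neither gap going beyond the scatter.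

Compound 4 `CNC(=O)CSc1nc(N)c(C#N)c(-c2ccc(OCC3CC3)cc2)c1C#N` has not yet been measured in this assay. Against compound 3 its difference is methylcarbamoyl in place of 1H-1,2,4-triazol-1-yl on a saturated chain carbon bound to a sulfur. Among the measured compounds shown here, every measured step so far sits at that same place, on a saturated chain carbon bound to a sulfur, and each of the three stayed within the scatter while the group there was varied widely. Those steps bear directly on the present change, and on their evidence no step beyond the scatter is expected. The step of no change at the digits printed from compound 3 to compound 4 (within the scatter) is therefore expected to remain within the scatter. Compound 4 is accordingly estimated to give 1%, with a range from -8% to 12%.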

Compound 4, a percentage reported as inhibition, at one concentration (the size of the read-out at that concentration, not a potency): 3%
Beside the measured number, compound 4's estimate is 2 percentage points below it; measured number inside the range.
By their numbers in this assay, from the lowest: compounds 1, 2, 3 and 4 (each within the scatter of the next).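

Compound 4 is the first compound shown whose group on a saturated chain carbon bound to a sulfur has no ring: compounds 1, 2 and 3 all carry a ring there, so their steps only exchanged one ring-bearing group for another. In this assay methylcarbamoyl in place of 1H-1,2,4-triazol-1-yl gives a number 2 percentage points higher from compound 3 to compound 4 (within the scatter) and in place of 1H-tetrazol-5-yl gives a number 2 percentage points higher from compound 2 to compound 4 (within the scatter) while in place of 3-carbamoylphenyl it gives a number 2 percentage points higher from compound 1 to compound 4 (within the scatter) so that, among these four compounds, the read-out at this place stays within the scatter with or without a ring in the group. Nothing available explains why the read-out holds across these groups.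

The compounds shown leave open whether a carboxylic acid, an amine or a longer alkyl chain on this same chain carbon would read differently from these four. On these data alone, all four also share the rest of the structure, so what a change elsewhere on the shared core would do in this assay remains open.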